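Replacing 2,4,5-trichlorophenyl with 2-bromophenyl on a shared core

A few compounds are considered here, and "the series" means these few. Any claim that something is new, unique, unknown or untested is made for them only; others in the source may bear on it.

Measured so far in a functional assay on HepG2 cells (Homo sapiens) for antiproliferative activity, read by MTT assay, with a stated time of 72 h; on this read-out higher numbers stand for weaker inhibition and lower numbers for stronger inhibition:
- Compound 1 `NC1=NC2(CCSCC2)N(OCCCOc2cccc(Cl)c2Cl)C(N)=N1` gives 50 nM
- Compound 2 `NC1=NC2(CCSCC2)N(OCCCOc2cc(Cl)c(Cl)cc2Cl)C(N)=N1` gives > 100000 nM (a limit, not a number)

Compound 2 has no exact position on the scale. Its reading of > 100000 nM is only a limit of this assay.

Compound 3 `NC1=NC2(CCSCC2)N(OCCCOc2ccccc2Br)C(N)=N1`, not yet measured, carries 2-bromophenyl in place of 2,4,5-trichlorophenyl on an oxygen on a saturated carbon. The core and the rest of the chain stay the same.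

Within the data shown here, one measured step bears on this change. It concerns the same place and the same leaving group, seen from the other side: an at least 2000-fold higher number from compound 1 to compound 2 (3.30 log units; beyond the scatter). Among the measured compounds shown here, this large step, well beyond the scatter, is the only evidence available. Compound 1 at 50 nM shows that a group other than 2,4,5-trichlorophenyl can give a low number here. However, 2-bromophenyl is a different group from the 2,3-dichlorophenyl of compound 1, so only part of that recovery is assumed.

A large move to a lower number is therefore expected, estimated as an at least 100-fold lower number from compound 2 to compound 3 (2.00 log units; beyond the scatter). For compound 3 the estimated value is 1000 nM, with an expected range from 50 nM to 30000 nM.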

Compound 3, half-maximal inhibitory concentration: 90 nM
Compound 3: the middle estimate sits 11-fold (1.05 log units) above what was measured; low and high end bracket the measured number.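

In this assay, the exchange of 2,4,5-trichlorophenyl for 2-bromophenyl gives an at least 1100-fold lower number from compound 2 to compound 3 (3.04 log units; beyond the scatter), and the reading of compound 2 on this scale is only a limit, so this step has no exact size: the limit of > 100000 nM in this assay, at which 1 of the 3 values shown sits. Set against the 2,3-dichlorophenyl of compound 1, the same 2-bromophenyl gives a 1.8-fold higher number from compound 1 to compound 3 (0.26 log units; within the scatter), so compound 1 and compound 3 cannot be told apart in this assay. This shows what compound 1 alone could not: a low number at this position is not tied to 2,3-dichlorophenyl, since a phenyl carrying a single bromine serves as well, and among the three compounds only compound 2, with its 2,4,5-trichlorophenyl, goes against this.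

The compounds shown leave open how a plain phenyl or a 2-chlorophenyl would read at this place, and therefore which of the chlorines of 2,4,5-trichlorophenyl goes with the high reading. They also leave open what an amine or a carboxylic acid in place of the halogenated phenyl would give, and what a longer chain would do to the low numbers.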